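A few compounds are considered here, and "the series" means these few. Any claim that something is new, unique, unknown or untested is made for them only; others in the source may bear on it.

Compound 1 `O=C(CCCc1ccccc1)Nc1nc2cc(Cl)ccc2c(=O)s1`: > 1000 nM
Compound 2 `O=C(CCCc1ccccc1)Nc1nc2ccccc2c(=O)s1`: > 1000 nM
Compound 3 `O=C(CCCc1ccccc1)Nc1nc2ccc(Br)cc2c(=O)s1`: > 1000 nM

In an assay on CHO cells for displacement of a labelled ligand from adenosine receptor A2b (Homo sapiens), read by scintillation counting, with a stated time of 75 min (a lower number here means a stronger inhibitor, a higher number a weaker inhibitor), compound 1 gives > 1000 nM, which is a limit of the assay and not a number. Compound 2 likewise gives > 1000 nM, also a limit. Compound 3 gives > 1000 nM, again only a limit. Compound 2 therefore stands at the limit of > 1000 nM in this assay, at which 3 of the 3 values shown sit, with nothing to set it apart from the other two. The two measured steps, a step that the two limits leave unreadable from compound 1 to compound 2 and a step that the two limits leave unreadable from compound 2 to compound 3, each swap a chloro or bromo for hydrogen on an aromatic carbon of the shared core, and neither can be sized. Compound 4 `O=C(CCc1ccc(Cl)c(Cl)c1)Nc1nc2ccccc2c(=O)s1` differs from compound 2 elsewhere: 3,4-dichlorophenyl in place of benzyl on a saturated chain carbon, two bonds along the chain from a carbonyl carbon. Among the measured compounds shown here, no measured step touches this part of the molecule, so the expected step that the limit leaves unreadable from compound 2 to compound 4 rests on no measured comparison. Compound 4 is expected to give about 1500 nM, within 300 nM to 10000 nM, with a limit again the likelier outcome.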

Compound 4, inhibition constant: > 1000 nM
Compound 4 ended at the assay's limit; the forecaster's own chance of this, stated with the estimate: 60%; the middle value does not contradict the limit.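

Compound 2 and compound 4 each give only a limit and not a number, so the step between them cannot be read: the limit of > 1000 nM in this assay, at which 4 of the 4 values shown sit. The compounds shown leave open how strongly any of them binds, and whether any of these group swaps changes that.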